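This account rests on a few compounds, and the source may have more. Where it says the series, first, only, none or still open, it means among the compounds named here.

Compound 2 `CCc1ccccc1-n1nncc1CN1C(=O)C2(C(C#N)=C(N)Oc3c(N)cc4nc5ccccc5nc4c32)c2ccccc21` is the only one of the two measured compounds that gives a number in a functional assay on HCT-116 cells (Homo sapiens) for antiproliferative activity, read by MTT assay, with a stated time of 48 h; on this read-out higher numbers stand for weaker inhibition and lower numbers for stronger inhibition: compound 2 gives 10300 nM. Compound 1 `Cc1ccc(-n2nncc2CN2C(=O)C3(C(C#N)=C(N)Oc4c3c3nc5ccccc5nc3c3ccccc43)c3ccccc32)cc1Cl` gives only a limit of the assay, > 50000 nM, which is the limit of > 50000 nM in this assay, at which 1 of the 2 values shown sits. Compound 3 `COc1ccccc1-n1nncc1CN1C(=O)C2(C(C#N)=C(N)Oc3c(N)cc4nc5ccccc5nc4c32)c2ccccc21` is not yet measured; it differs from compound 2 by methoxy in place of ethyl on an aromatic carbon. Among the compounds with values here, no measured step resembles this change, so the expected step is none beyond the scatter, in neither direction. Compound 3 is therefore expected to give 10000 nM in this assay, between 3500 nM and 30000 nM. The expected step is a 1.0-fold lower number from compound 2 to compound 3 (0.01 log units; within the scatter).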

Compound 3, half-maximal inhibitory concentration: > 50000 nM
Compound 3: no number, only a limit; the forecaster's own chance of this, stated with the estimate: 15%; middle value at least 5.0-fold (0.69 log units) away from the limit.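

Within the data shown here, replacing ethyl with methoxy on this aromatic carbon, ortho to a large group, is the first change here that can be read as a step, and it matters: in this assay it gives an at least 4.8-fold higher number from compound 2 to compound 3 (0.68 log units; beyond the scatter). The two groups have the same heavy-atom count, so even a swap of this size at this carbon can take the compound out of the measurable range. The step shows only a minimum size, as compound 3 gives a limit and not a number: the limit of > 50000 nM in this assay, at which 2 of the 3 values shown sit.

The compounds shown leave open whether the oxygen itself or the absence of ethyl accounts for the step. From the compounds shown here alone, how an amine or a propyl chain at this carbon would read also remains open.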